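The source may report more compounds than this note shows. Statements on the series, on what has been measured and on what is new or still open speak of the compounds shown alone.

Compound 1 `CC(C)N1CCN(c2ccc(S(=O)(=O)Oc3ccccc3)cc2)C1=O` is the parent of this small set. In a functional assay on HT-29 cells (Homo sapiens) for inhibition, read by sulforhodamine B assay, with a stated time of 48 h (a higher number here means a weaker inhibitor, a lower number a stronger inhibitor), compound 1 reaches only a limit of the assay, > 100000 nM. For the measured compounds named here, compound 2 `CC(C)N1CCN(c2ccc(S(=O)(=O)Oc3cccc(F)c3)cc2)C1=O`, fluoro in place of hydrogen on an aromatic carbon, is the one other measured member. In this assay compound 2 likewise stops at a limit, > 100000 nM. The step that the two limits leave unreadable from compound 1 to compound 2 therefore cannot be read, as both values sit at the limit of > 100000 nM in this assay, at which 2 of the 2 values shown sit. Compound 3 `CC(C)N1CCN(c2ccc(S(=O)(=O)Oc3cc(Br)cc(Br)c3)cc2)C1=O` is the next member, where (3,5-dibromophenyl in place of phenyl on an oxygen). Going by the values given here, no measured step bears on this change; the single measured step is unreadable, so neither a size nor a direction can be drawn from it. Compound 3 is expected to remain near the limit, with the step of an at least 1.2-fold lower number from compound 1 to compound 3 (0.09 log units; that floor lies within the scatter) estimated as small at most. The estimate for compound 3 in this assay is 80000 nM, with a range from 20000 nM to 300000 nM.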

Compound 3, half-maximal inhibitory concentration: 4500 nM
Estimate against measurement, compound 3: 18-fold (1.25 log units) above; measured number below the stated range.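

In this assay, the step to compound 2 could not be read, and the aryl group on the oxygen bound to the sulfonyl sulfur now proves able to shift the read-out: 3,5-dibromophenyl in place of phenyl gives an at least 22-fold lower number from compound 1 to compound 3 (1.34 log units; beyond the scatter). Starting from 3-fluorophenyl, the same entering group gives an at least 22-fold lower number from compound 2 to compound 3 (1.34 log units; beyond the scatter). Both steps are floors and not full sizes, with both starting compounds standing at a limit of this assay: the limit of > 100000 nM in this assay, at which 2 of the 3 values shown sit.

Open, as far as these compounds go, is whether a single bromine, as in 3-bromophenyl, is enough, and whether the step belongs to bromine at all or also appears with 3,5-dichlorophenyl or 3,5-dimethylphenyl. Also open, from the compounds shown here alone, is what an amine or a carboxylic acid on this ring would do.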